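The source may report more compounds than this note shows. Statements on the series, on what has been measured and on what is new or still open speak of the compounds shown alone.

Measured compounds:
- compound 1, `Oc1ccc(-c2cc(-c3ccsc3)nc(-c3ccccc3Cl)c2)cc1`: 5930 nM
- compound 2, `Oc1cccc(-c2cc(-c3ccccc3)nc(-c3ccccc3Cl)c2)c1`: 1760 nM

Both compounds were tested in an ADME assay on HEK293 cells (Homo sapiens) for cytotoxicity, read by CCK-8 assay and cell counting, with a stated time of 2 days; a higher number here means a weaker inhibitor, a lower number a stronger inhibitor. In this assay compound 1 gives 5930 nM, and compound 2 gives 1760 nM. Compound 2 holds the lowest of the two numbers; its nearest neighbour, compound 1, sits higher by a margin beyond the usual scatter, so the two are genuinely told apart.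

Compound 3, `Oc1cccc(-c2cc(-c3ccsc3)nc(-c3ccccc3Cl)c2)c1`, has not yet been measured. It differs from compound 2 in one place: thiophen-3-yl in place of phenyl on an aromatic carbon. Among the compounds with values here, compound 1 carries the same thiophen-3-yl group, yet it also differs from compound 3 in its hydroxyphenyl group, so no measured pair isolates this single exchange. With the two shared pieces pointing in opposite directions, only a modest step is expected in this assay, leaning toward a somewhat higher number. Compound 3 is therefore estimated at 3000 nM, with a range from 1200 nM to 8000 nM. The step of a 1.7-fold higher number from compound 2 to compound 3 (0.23 log units; within the scatter) that this estimate implies is expected to remain close to the scatter.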

Compound 3, half-maximal inhibitory concentration: 2720 nM
For compound 3 the middle estimate is 1.1-fold (0.04 log units) above the measured one, and the stated range covers the measured number.
By their numbers in this assay, from the lowest: compounds 2 and 3 (each within the scatter of the next); then compound 1.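

In this assay the aromatic carbon next to the ring nitrogen takes thiophen-3-yl in place of phenyl without a readable effect: the exchange gives a 1.5-fold higher number from compound 2 to compound 3 (0.19 log units; within the scatter) and leaves compound 2 and compound 3 within the scatter of each other. For this pair, then, a five-membered ring with one sulfur atom and a six-membered ring of carbon only cannot be told apart at this position. The clearer difference lies in the hydroxyphenyl group, where 3-hydroxyphenyl in place of 4-hydroxyphenyl gives a 2.2-fold lower number from compound 1 to compound 3 (0.34 log units; beyond the scatter) and this modest step stands beyond the scatter. No supporting measurement here explains either step.

The compounds shown leave open whether a group of a different kind on the same carbon, such as an amine, a carboxylic acid or a longer alkyl chain, would move the number further than thiophen-3-yl does. Within the data shown here, it also remains open whether the hydroxyl shift would give a similar step with phenyl on that carbon, since the only direct comparison of the two hydroxyphenyl groups carries thiophen-3-yl.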